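Notes on the step from compound 3 to compound 4

The source may hold more compounds than are shown below. What is called first, only, known or untested is meant among the compounds shown, and "the series" means these compounds.

Measured so far in an assay on HEK293 cells for inhibition of Voltage-dependent T-type calcium channel subunit alpha-1H (Homo sapiens), read by patch clamp, using a membrane potential dye; a higher number here means a weaker inhibitor, a lower number a stronger inhibitor:
compound 1 `CN1CC2(CCN(C(=O)Nc3cc(F)cc(F)c3)CC2)C1c1ccc(Cl)cc1`: 214 nM
compound 2 `CC[C@H](C)[C@H](NC(=O)N1CCC2(CC1)CN(c1cccc(F)c1)C2c1ccc(Cl)cc1)C(=O)OC`: 146 nM; 3200 nM (2 entries)
compound 3 `CC[C@H](C)[C@H](NC(=O)N1CCC2(CC1)C(=O)N(c1cccc(F)c1)C2c1ccc(Cl)cc1)C(=O)NC`: 182 nM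

Among the measured compounds shown here, on the single numbers, compound 3 stands lowest of the two; compound 1 sits within the scatter of it, so no order between them is claimed. Compound 2 carries several entries the several entries of compound 2 in this assay, 146 nM; 3200 nM (2 entries) and gives no single number.

Compound 4 `CC[C@H](NC(=O)N1CCC2(CC1)C(=O)N(c1cccc(F)c1)C2c1ccc(Cl)cc1)c1ccccc1` differs from compound 3 by 1-phenylpropyl in place of 2-methyl-1-(methylcarbamoyl)butyl on an amide-type nitrogen. For the measured compounds named here, no step between measured compounds is recorded, so the size of this change is unknown from the series; the varied groups at that place among compounds 1 to 3 all gave numbers in a narrow band. A step no larger than the scatter is expected in this assay, if anything toward a weaker inhibitor. Compound 4 is estimated at 300 nM, range 100 nM to 1000 nM, which means an expected step of a 1.6-fold higher number from compound 3 to compound 4 (0.22 log units; within the scatter).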

Compound 4, half-maximal inhibitory concentration: 224 nM
For compound 4 the middle estimate is 1.3-fold (0.13 log units) above the measured one, within the range that was stated.
By their numbers in this assay, from the lowest: compounds 3, 1 and 4 (each within the scatter of the next).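

In this assay, 1-phenylpropyl in place of 2-methyl-1-(methylcarbamoyl)butyl on the amide-type nitrogen gives a 1.2-fold higher number from compound 3 to compound 4 (0.09 log units; within the scatter). The entering group has no hydrogen-bond donor or acceptor, so for this pair neither feature of the leaving group is needed to keep the number within the scatter. Nothing measured here bears on why the step is this small.

Going by these compounds, whether a carboxylic acid or an amine on the phenyl ring would keep the number there remains open. So does the effect of a longer chain in place of the ethyl part of 1-phenylpropyl.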